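Naphthalen-1-yl for Pentan-3-yl: Acid Dissociation Expected Unchanged

The compounds below may be only part of what the source reports. "The series", "measured", "known", "first", "only" and "open" are said of these compounds alone.

Compound 2 `CCC(CC)c1ccc2c(NCCCNCc3cccc(OC)c3O)ccnc2c1` was examined in a physicochemical assay for acid dissociation, where compound 2 gives 9.47. Compound 1 `CC(C)CCc1ccc2c(NCCCNCc3ccco3)ccnc2c1` gives 9.47 in this assay, and compound 3 `COc1ccc(F)cc1CNCCCNc1ccnc2cc(Cc3ccc(F)cc3)ccc12` gives 9.47. At the digits given, compound 2 stands level with both companions: its nearest neighbour is compound 1 and its furthest is compound 3, and in each case the gap lies within the scatter of the measurement. Three compounds on the shared core, though differing elsewhere in their structures, thus return the same reading.

Compound 4 `COc1cccc(CNCCCNc2ccnc3cc(-c4cccc5ccccc45)ccc23)c1O` has not yet been measured in this assay. It differs from compound 2 by a single change: naphthalen-1-yl in place of pentan-3-yl on an aromatic carbon. Among the measured compounds shown here, no measured pair that differs in only one place is available to size such a step directly. Because compounds 1 and 3 sit together with compound 2 at 9.47 despite their structural differences, the step from compound 2 to compound 4 is expected to be none beyond the scatter, no change at the digits printed from compound 2 to compound 4 (within the scatter). Compound 4 is therefore estimated to give about 9.47 in this assay, with the expected range running from 9.15 to 9.8.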

Compound 4, acid dissociation constant: 9.47
The estimate for compound 4 equals the measured number at the digits printed; the range from low to high includes it.
By their numbers in this assay, from the lowest: compounds 1, 2, 3 and 4 (each within the scatter of the next).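

In this assay, the exchange of pentan-3-yl for naphthalen-1-yl on an aromatic carbon of the shared core gives no change at the digits printed from compound 2 to compound 4 (within the scatter), the only step shown that compares two compounds differing in one place. The earlier compounds shown here agreed only across several structural differences, whereas this pair isolates a single position and a single change: an open group of 5 heavy atoms with no ring gives way to a group of 10 heavy atoms with 2 six-membered aromatic rings of carbon only, and the reading shows no difference beyond the scatter. Nothing in the data shown accounts for this outcome.

From the compounds shown here alone, both groups consist of carbon only and carry no hydrogen-bond donors or acceptors, so the reading with an amine or a carboxylic acid at this position remains open. This single pair also leaves open whether the same exchange would read alike with a different side chain on the shared core, such as that of compound 1.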